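This account rests on a few compounds, and the source may have more. Where it says the series, first, only, none or still open, it means among the compounds named here.

Measured compounds, read in a functional assay on NCI-H226 cells (Homo sapiens) for cytotoxicity, read by sulforhodamine B assay, with a stated time of 48 h, tested at 0.01 uM; a higher number here means a weaker effect of the compound at the concentration tested, a lower number a stronger effect:
Compound 1 `COc1cc(-c2cc(/C=C/C(=O)c3ccc(Cl)c(Cl)c3)[nH]n2)cc(OC)c1OC`: 103%
Compound 2 `COc1ccc(-c2cc(/C=C/C(=O)c3cc(OC)c(OC)c(OC)c3)[nH]n2)cc1OC`: 93%
Compound 3 `COc1ccc(-c2cc(/C=C/C(=O)c3ccc(N)cc3)[nH]n2)cc1`: 102%

Compound 1 gives the highest of the three numbers in this assay, but the nearest value, that of compound 3, and the furthest, that of compound 2, both lie lower by gaps that fall within the usual scatter, so no order among the three can be read from these numbers. All three compounds share the same core and leave the cells essentially untouched at the concentration tested.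

The next compound, compound 4 `COc1ccc(C(=O)/C=C/c2cc(-c3cc(OC)c(OC)c(OC)c3)n[nH]2)cc1OC`, differs from compound 1 in one place: 3,4-dimethoxyphenyl in place of 3,4-dichlorophenyl on a carbonyl carbon. Among the compounds with values here, no step between two measured compounds isolates this kind of exchange, so there is nothing measured to lean on beyond the flat picture given by compounds 1, 2 and 3. Given that compound 2, which also carries methoxy groups on the aryl attached to the carbonyl carbon, sits at 93%, no movement beyond the scatter is expected in this assay, and the step from compound 1 to compound 4 is estimated at a number 4 percentage points lower from compound 1 to compound 4 (within the scatter). For compound 4 the expected read-out in this assay is 99%, with a range from 88% to 110%.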

Compound 4, a percentage reported as activity, at one concentration (the size of the read-out at that concentration, not a potency): 98%
Compound 4: middle estimate off by 1 percentage points, on the high side; the range from low to high includes it.
By their numbers in this assay, from the lowest: compounds 2, 4, 3 and 1 (each within the scatter of the next).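

In this assay, within the data shown here, exchanging 3,4-dichlorophenyl for 3,4-dimethoxyphenyl on the carbonyl carbon gives the only single-place step so far, a number 5 percentage points lower from compound 1 to compound 4 (within the scatter), so this position accepts the exchange with no change in the read-out beyond the scatter. The comparison holds although the two groups differ in make-up: the leaving group carries two chlorine atoms and 0 hydrogen-bond acceptors, the entering group two oxygen atoms and 2 hydrogen-bond acceptors. Nothing available on these compounds bears on why the read-out stays level across this exchange.

Going by these compounds, with every read-out taken at a single concentration at which the cells remain essentially untouched, it stays open whether the two aryl groups would separate at a higher concentration, and the step says nothing about potency. Also open, on these data alone, is how this position would read with a carboxylic acid on the aryl ring, a longer alkoxy chain in place of the methoxy groups, or a saturated cyclohexyl ring in place of the aryl group on the carbonyl carbon.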